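Replacing the Dihydroxypropyl Group of Compound 1

The compounds below may be only part of what the source reports. "The series", "measured", "known", "first", "only" and "open" are said of these compounds alone.

Going by the values given here, in a functional assay on Daudi cells (Homo sapiens) for antiproliferative activity (on this read-out lower numbers stand for stronger inhibition and higher numbers for weaker inhibition), compound 1 (`Nc1ncnc2c1c(-c1ccc(Oc3ccccc3)cc1)cn2C[C@H]1CCCN1C[C@@H](O)CO`) gives 14400 nM, the highest of the three numbers measured so far. Compound 2 (`Nc1ncnc2c1c(-c1ccc(C(=O)Nc3ccc(Oc4ccccc4)cc3)cc1)cn2[C@H]1CCN(C[C@@H]2CO2)C1`) gives 4390 nM and compound 3 (`Nc1ncnc2c1c(-c1cc3ccccc3o1)cn2[C@H]1CCN(C[C@@H]2CO2)C1`) gives 4510 nM. Each of these two numbers lies lower than that of compound 1 by more than the scatter, though neither compound differs from it in one place only.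

Compound 4 (`Nc1ncnc2c1c(-c1ccc(Oc3ccccc3)cc1)cn2[C@H]1CCN(C[C@@H]2CO2)C1`) has not yet been measured. It keeps the core of compound 1 and carries 1-((oxiran-2-yl)methyl)pyrrolidin-3-yl in place of (1-(2,3-dihydroxypropyl)pyrrolidin-2-yl)methyl on an aromatic nitrogen. Among the compounds with values here, no measured step isolates this change, so the only guide is indirect. The entering group is also present in compound 2 at 4390 nM and in compound 3 at 4510 nM, although both have a different group elsewhere on the core.

A move towards stronger inhibition is therefore expected, with the estimated step being a 4.1-fold lower number from compound 1 to compound 4 (0.61 log units; beyond the scatter). For compound 4, the estimated value in this assay is 3500 nM, within an expected range of 800 nM to 12000 nM.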

Compound 4, half-maximal inhibitory concentration: 5480 nM
Compound 4: middle estimate off by 1.6-fold (0.19 log units), on the low side; measured number inside the range.
By their numbers in this assay, from the lowest: compounds 2, 3 and 4 (each within the scatter of the next); then compound 1.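

In this assay, putting 1-((oxiran-2-yl)methyl)pyrrolidin-3-yl in place of (1-(2,3-dihydroxypropyl)pyrrolidin-2-yl)methyl on the aromatic nitrogen gives a 2.6-fold lower number from compound 1 to compound 4 (0.42 log units; beyond the scatter), so this position now has a directly measured step, modest but beyond the scatter. With that group in place, compound 4 sits with compound 2 and compound 3, each within the scatter of the next, although these three differ elsewhere on the core. Nothing measured here explains the step.

The change alters the ring attachment, the linker and the end group at once, so this single step cannot show which of these accounts for it. On these data alone, how a 1-(2,3-dihydroxypropyl)pyrrolidin-3-yl or a 1-acryloylpyrrolidin-3-yl group would compare at this position remains open.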